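Replacing the hexyloxy chain of compound 3 with a dimethoxybenzyl ether

This account rests on a few compounds, and the source may have more. Where it says the series, first, only, none or still open, it means among the compounds named here.

Three measured anilides share one core. Compound 1 `CCCCCCOc1cc(NC(=O)c2ccc(Br)cc2)ccc1N(C)S(C)(=O)=O` gives 39900 nM in a functional assay on SK-BR-3 cells (Homo sapiens) for antiproliferative activity, read by MTT assay, with a stated time of 48 h; on this read-out lower numbers stand for stronger inhibition and higher numbers for weaker inhibition; compound 2 `CCCCCCOc1cc(NC(=O)c2ccc(OC)cc2)ccc1N(C)S(C)(=O)=O` gives 20000 nM in this assay; compound 3 `CCCCCCOc1cc(NC(=O)c2ccc3ccccc3c2)ccc1N(C)S(C)(=O)=O` gives 64300 nM in this assay, the highest of the three numbers, with the step of a 1.6-fold higher number from compound 1 to compound 3 (0.21 log units; within the scatter) within the scatter and the step of a 3.2-fold higher number from compound 2 to compound 3 (0.51 log units; beyond the scatter) beyond it. Compound 4 `COc1ccc(OC)c(COc2cc(NC(=O)c3ccc4ccccc4c3)ccc2N(C)S(C)(=O)=O)c1` differs from compound 3 by 2,5-dimethoxyphenyl in place of pentyl on a saturated chain carbon bound to an oxygen on an aromatic ring. Every measured step changes the amide aryl group, not the ether chain, so none bears directly on this change, and no direction beyond the scatter can be expected with confidence. The author therefore expects a step of a 1.3-fold lower number from compound 3 to compound 4 (0.11 log units; within the scatter) in this assay, with compound 4 estimated at 50000 nM, in a range from 10000 nM to 200000 nM.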

Compound 4, half-maximal inhibitory concentration: 16.6 nM
Beside the measured number, compound 4's estimate is 3000-fold (3.48 log units) above it, outside the stated range (below it).
By their numbers in this assay, from the lowest: compound 4; then compounds 2, 1 and 3 (each within the scatter of the next, the first and the last beyond it).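

The ether position proves far more sensitive in this assay than the amide aryl group: hexyloxy to (2,5-dimethoxybenzyl)oxy gives a 3900-fold lower number from compound 3 to compound 4 (3.59 log units; beyond the scatter), whereas the largest step from changing the amide aryl group was a 3.2-fold higher number from compound 2 to compound 3 (0.51 log units; beyond the scatter). Nothing measured here explains this gain. The compounds shown leave open whether a plain benzyl ether would keep this activity or whether the two methoxy groups are required. They also leave open whether the same exchange would carry over to the 4-bromophenyl and 4-methoxyphenyl amides.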